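The compounds below may be only part of what the source reports. "The series", "measured", "known", "first", "only" and "open" are said of these compounds alone.

Compound 3 `C=CC(=O)OC1CCC(CN2CCN(c3cc(=O)c4cc(C(F)(F)F)cc([N+](=O)[O-])c4s3)CC2)CC1` in an ADME assay on Vero cells (Chlorocebus sabaeus) for cytotoxicity, read by MTT assay, with a stated time of 48 h (a higher number here means a weaker inhibitor, a lower number a stronger inhibitor), gives > 64 ug/mL, which is a limit of the assay and not a number. Compound 1 `CS(=O)(=O)NC1CCC(CN2CCN(c3cc(=O)c4cc(C(F)(F)F)cc([N+](=O)[O-])c4s3)CC2)CC1` gives 48.5 ug/mL in this assay. Compound 2 `Cc1ccc(C(=O)OC2CCC(CN3CCN(c4cc(=O)c5cc(C(F)(F)F)cc([N+](=O)[O-])c5s4)CC3)CC2)cc1` gives > 64 ug/mL, again a limit. The measured steps run as an at least 1.3-fold higher number from compound 1 to compound 3 (0.12 log units; that floor lies within the scatter), an at least 1.3-fold higher number from compound 1 to compound 2 (0.12 log units; that floor lies within the scatter) and a step that the two limits leave unreadable from compound 2 to compound 3; the last cannot be read given (the limit of > 64 ug/mL in this assay, at which 2 of the 3 values shown sit). Compound 4 `CC(=O)OC1CCC(CN2CCN(c3cc(=O)c4cc(C(F)(F)F)cc([N+](=O)[O-])c4s3)CC2)CC1` differs from compound 3 by methyl in place of vinyl on a carbonyl carbon. Among the measured compounds shown here, the one step at a carbonyl carbon, from compound 2 to compound 3, is the only step bearing on this change, and it is unreadable, so no step beyond the scatter is expected: the estimated step is a step that the limit leaves unreadable from compound 3 to compound 4. Compound 4 is expected to give 70 ug/mL, between 35 ug/mL and 140 ug/mL, most probably again only a limit.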

Compound 4, half-maximal inhibitory concentration: > 64 ug/mL
Compound 4 ended at the assay's limit (the forecaster's own chance of this, stated with the estimate: 65%); the middle value does not contradict the limit.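

With a methyl on the carbonyl carbon, compound 4 stays at the same limit as the vinyl of compound 3 and the 4-methylphenyl of compound 2, so the vinyl double bond is not needed to stay there, and the steps among these three esters cannot be read: the limit of > 64 ug/mL in this assay, at which 3 of the 4 values shown sit. In this assay the acetoxy ester gives an at least 1.3-fold higher number from compound 1 to compound 4 (0.12 log units; that floor lies within the scatter), so the third ester also shows no separation beyond the scatter from the methanesulfonamido compound.

Still open, going by these compounds, is how far any of these esters lies above the limit. Also open, on these data alone, is whether an amine or a free hydroxyl on this saturated ring carbon would bring the value within range.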